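The source may hold more compounds than are shown below. What is called first, only, known or untested is meant among the compounds shown, and "the series" means these compounds.

Values in a functional assay on HT-29 cells (Homo sapiens) for antiproliferative activity, read by sulforhodamine B assay, with a stated time of 48 h; on this read-out lower numbers stand for stronger inhibition and higher numbers for weaker inhibition
compound 1 `CCCCN1CCN(c2ccc(S(=O)(=O)Oc3cccc(OC)c3)cc2)C1=O` gives 13000 nM
compound 2 `CCCCN1CCN(c2ccc(S(=O)(=O)Oc3cc(F)cc(F)c3)cc2)C1=O` gives > 100000 nM (a limit of the assay, not a number)
compound 3 `CCCCN1CCN(c2ccc(S(=O)(=O)Oc3cc(Br)cc(Br)c3)cc2)C1=O` gives 43000 nM

Compound 3 at 43000 nM holds the higher of the two actual numbers, with compound 1 the lower. Compound 4 `CCCCN1CCN(c2ccc(S(=O)(=O)Oc3ccc(OC)cc3)cc2)C1=O` has 4-methoxyphenyl in place of 3,5-dibromophenyl on an oxygen whose other neighbour is the sulfonyl sulfur (4-methoxyphenyl in place of 3,5-dibromophenyl on an oxygen). The nearest measured guide is a 3.3-fold higher number from compound 1 to compound 3 (0.52 log units; beyond the scatter) with 3,5-dibromophenyl in place of 3-methoxyphenyl. The change here runs the other way, back to a methoxyphenyl. A step of similar size towards a lower number is therefore expected, estimated as a 2.9-fold lower number from compound 3 to compound 4 (0.46 log units; beyond the scatter) in this assay on the strength of that single step. For compound 4 the estimated value is 15000 nM with an expected range of 4000 nM to 50000 nM.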

Compound 4, half-maximal inhibitory concentration: 35000 nM
Estimate against measurement, compound 4: 2.3-fold (0.37 log units) below; the range from low to high includes it.
By their numbers in this assay, from the lowest: compound 1; then compounds 4 and 3 (each within the scatter of the next). At a limit, above all of these: compound 2.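

In this assay, 4-methoxyphenyl in place of 3-methoxyphenyl gives a 2.7-fold higher number from compound 1 to compound 4 (0.43 log units; beyond the scatter), so the methoxyphenyl group alone does not carry the value of compound 1; where the methoxy group sits matters. Against 3,5-dibromophenyl, the same group gives a 1.2-fold lower number from compound 3 to compound 4 (0.09 log units; within the scatter), which leaves these two groups unseparated at this position. Against 3,5-difluorophenyl it gives an at least 2.8-fold lower number from compound 2 to compound 4 (0.45 log units; beyond the scatter), a step that rests on a limit for compound 2: the limit of > 100000 nM in this assay, at which 1 of the 4 values shown sits.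

Open, on these data alone, is how a phenyl carrying an amine or a carboxylic acid would read on this oxygen in this assay.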